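Swapping ethyl for cyclopentyl on an amide-type nitrogen

The source may hold more compounds than are shown below. What is called first, only, known or untested is meant among the compounds shown, and "the series" means these compounds.

compound 1 `CCC1C(=O)N(C)c2cnc(-n3ccc4cc(C(=O)NC)ccc43)nc2N1c1ccn(C)n1`: 6330 nM
compound 2 `CCC1C(=O)N(C)c2cnc(-n3ccc4cc(F)ccc43)nc2N1c1ccn(C)n1`: "not active" (no number reported)
compound 3 `CCNC(=O)c1ccc2c(ccn2-c2ncc3c(n2)N(c2ccn(C)n2)C(CC)C(=O)N3C)c1`: 11100 nM

Within the data shown here, all three were tested in a functional assay on HeLa cells (Homo sapiens) for antiproliferative activity, read by CCK-8 assay, with a stated time of 72 h (a lower number here means a stronger inhibitor of growth, a higher number a weaker inhibitor of growth), and only two gave a number. Compound 2 gives "not active" (no number reported) and so offers nothing to compare. Among the measured compounds shown here, compound 3 gives 11100 nM and compound 1 gives 6330 nM, which places compound 3 level with the only other number, inside the scatter. The measured step is a 1.8-fold higher number from compound 1 to compound 3 (0.24 log units; within the scatter) and it puts methyl in place of hydrogen on a saturated chain carbon bound to an amide-type nitrogen.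

Compound 4 `CCC1C(=O)N(C)c2cnc(-n3ccc4cc(C(=O)NC5CCCC5)ccc43)nc2N1c1ccn(C)n1` keeps the rest of compound 3 but carries cyclopentyl in place of ethyl on an amide-type nitrogen. For the measured compounds named here, only one measured change bears on this, and it touched the same amide-type nitrogen group. That change gave a 1.8-fold higher number from compound 1 to compound 3 (0.24 log units; within the scatter), so no step beyond the scatter is expected in this assay, perhaps a slight rise at most. The new group is larger than any measured so far, which leaves this expectation loose, and a result with no number is also possible. The estimated step is a 1.3-fold higher number from compound 3 to compound 4 (0.10 log units; within the scatter) in size. For compound 4 the expected value is 14000 nM, with an estimated range from 5500 nM to 35000 nM in repeated measurements.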

Compound 4, concentration for 50% growth inhibition: 27400 nM
Estimate against measurement, compound 4: 2.0-fold (0.29 log units) below; measured number inside the range.
By their numbers in this assay, from the lowest: compounds 1 and 3 (each within the scatter of the next); then compound 4.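

In this assay, putting cyclopentyl in place of ethyl on this amide-type nitrogen gives a 2.5-fold higher number from compound 3 to compound 4 (0.39 log units; beyond the scatter), and putting it in place of methyl gives a 4.3-fold higher number from compound 1 to compound 4 (0.64 log units; beyond the scatter), so both steps lie beyond the scatter. This position therefore does respond to the group it carries, a response that the change from compound 1 to compound 3 could not show, since a 1.8-fold higher number from compound 1 to compound 3 (0.24 log units; within the scatter) stays inside the scatter, and among the compounds with a number, compound 4 is the weakest inhibitor of growth, although the steps are modest. Nothing available here accounts for this rise.

The compounds shown cannot separate the effect of the ring from that of the added carbons, a question that a straight pentyl chain or a cyclopropyl ring on the same nitrogen would address. As far as these compounds go, it also remains open how this position would respond to a group that is not made of carbon only, such as an amine or a carboxylic acid at the end of the chain.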